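From Trifluoromethoxy to Ethoxy in Compound 4

The compounds below may be only part of what the source reports. "The series", "measured", "known", "first", "only" and "open" are said of these compounds alone.

compound 1 `CCn1c(C(=O)NCC#N)ccc1C(CC)(CC)c1ccc(OCCC(O)(CC)CC)c(C)c1`: > 50000 nM (a limit)
compound 2 `C=CCN(C)C(=O)c1ccc(C(CC)(CC)c2ccc(OCCC(O)(CC)CC)c(C)c2)n1CC`: 1190 nM
compound 3 `CCn1c(C(=O)Nc2ccc(OC(F)(F)F)cc2)ccc1C(CC)(CC)c1ccc(OCCC(O)(CC)CC)c(C)c1`: > 50000 nM (a limit)

In an ADME assay on L02 cells (Homo sapiens) for antiproliferative activity, read by MTT assay, with a stated time of 48 h (on this read-out lower numbers stand for stronger inhibition and higher numbers for weaker inhibition), compound 3 gives > 50000 nM, which is a limit of the assay and not a number. Compound 1 and compound 3 both stand at the limit of > 50000 nM in this assay, at which 2 of the 3 values shown sit. Only compound 2 gives a number.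

Compound 4 `CCOc1ccc(NC(=O)c2ccc(C(CC)(CC)c3ccc(OCCC(O)(CC)CC)c(C)c3)n2CC)cc1` differs from compound 3 by ethyl in place of trifluoromethyl on an oxygen on an aromatic ring, so that trifluoromethoxy becomes ethoxy. Within the data shown here, no measured step changes this place. The nearest evidence comes from changes to the group on the carbonyl carbon. Bringing in (4-(trifluoromethoxy)phenyl)amino gave an at least 42-fold higher number from compound 2 to compound 3 (1.62 log units; beyond the scatter), a large step, and the reverse kind of contrast appears in an at least 42-fold lower number from compound 1 to compound 2 (1.62 log units; beyond the scatter). The remaining step, a step that the two limits leave unreadable from compound 1 to compound 3, cannot be read.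

Compound 4 keeps a substituted phenylamino group on the carbonyl carbon, as compound 3 does, so it is expected to stay far from compound 2 and close to the limit. The estimated change, a number no higher from compound 3 to compound 4 (the limit leaves the size open), is expected to be no clear gain in this assay. Compound 4 is expected at about 50000 nM, with an estimated range from 15000 nM to 100000 nM.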

Compound 4, half-maximal inhibitory concentration: > 50000 nM
Compound 4 gave a limit, no number; the forecaster's own chance of this, stated with the estimate: 60%; the middle value lies on the limit itself.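

Exchanging trifluoromethyl for ethyl on the oxygen on the aromatic ring leaves compound 4 at > 50000 nM in this assay, which is a limit of the assay and not a number. The steps that join compound 4 to compound 3 and to compound 1 cannot be read, as both ends of each are limits, so any difference between trifluoromethoxy and ethoxy stays hidden. What the new compound adds is a second substituted phenylamino group on the carbonyl carbon that stands far from the allyl(methyl)amino amide, with an at least 42-fold higher number from compound 2 to compound 4 (1.62 log units; beyond the scatter), and it joins the compounds gathered at the limit: the limit of > 50000 nM in this assay, at which 3 of the 4 values shown sit.

The compounds shown leave open whether a methyl or a longer chain on this oxygen, or a hydroxyl or an amine in place of ethoxy, would bring a phenylamino compound down to a readable number. They also leave open whether allyl(methyl)amino is unusual among amides on this carbonyl carbon, or whether dimethylamino or a piperidine amide would give a number as well.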